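Chloro for methyl on the ester-bearing core

The source may report more compounds than this note shows. Statements on the series, on what has been measured and on what is new or still open speak of the compounds shown alone.

Three compounds have numbers in an assay on HEK293 cells for inhibition of transient receptor potential cation channel subfamily M member 8 (Homo sapiens), read by FLIPR, with stated times of 5 min and 3 min; on this read-out higher numbers stand for weaker inhibition and lower numbers for stronger inhibition. Compound 1 `CCn1nnc(-c2sc(-c3ccccc3O)nc2O)n1` gives 24 nM. Compound 3 `CCn1nnc(-c2sc(-c3ccccc3C)nc2O)n1` differs from compound 1 in one place; compound 3 gives 60 nM, and the step is a 2.5-fold higher number from compound 1 to compound 3 (0.40 log units; beyond the scatter). Compound 2 `CCOC(=O)c1sc(-c2ccc(C)cc2)nc1O` gives 160 nM, the highest of the three numbers; compound 3 stands nearest to compound 2 and compound 1 furthest, both gaps beyond the scatter.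

The next compound is compound 4 `CCOC(=O)c1sc(-c2ccc(Cl)cc2)nc1O`, which differs from compound 2 as follows: chloro in place of methyl on an aromatic carbon. Among the measured compounds shown here, no measured pair shows this exchange. For the measured compounds named here, the only measured step, from compound 1 to compound 3, concerns methyl replacing hydroxy on a different core and does not bear on chloro replacing methyl. Going by the values given here, with no step to lean on, the expectation for compound 4 is a number close to that of compound 2, with no step beyond the scatter in either direction, and the estimated step is no change at the digits printed from compound 2 to compound 4 (within the scatter). Compound 4 is therefore estimated at 160 nM, with a range from 60 nM to 420 nM.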

Compound 4, half-maximal inhibitory concentration: 550 nM
For compound 4 the middle estimate is 3.4-fold (0.54 log units) below the measured one, and the stated range ends below it.
By their numbers in this assay, from the lowest: compound 1; then compound 3; then compound 2; then compound 4.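

The place para to a large group on the six-membered aromatic ring of carbon only is sensitive to this exchange: in this assay, chloro in place of methyl gives a 3.4-fold higher number from compound 2 to compound 4 (0.54 log units; beyond the scatter) and moves the ester-bearing series away from the lower numbers of compound 1 and compound 3. The exchange swaps one heavy atom for one heavy atom with no change in the counted hydrogen-bond donors, hydrogen-bond acceptors or net charge, yet methyl is the better of the two here. No measurement at hand accounts for this step.

On these data alone, whether chloro and methyl rank the same way on the core of compound 1 remains open. Also open, as far as these compounds go, is how a fluoro, a methoxy or a nitrile would stand at this place relative to methyl and chloro.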